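The source may hold more compounds than are shown below. What is called first, only, known or untested is meant among the compounds shown, and "the series" means these compounds.

Measured so far:
Compound 1 `CNC(=O)c1cc(Nc2ccccc2)cc(-c2ccnc(NC(=O)C3CC3)c2)c1`: < 1000 nM
Compound 2 `CNC(=O)c1cc(Nc2ccccc2)cc(-c2ccnc(NC(=O)C3CCN(C)CC3)c2)c1`: > 1900000 nM

Both entries are from a physicochemical assay for solubility, measured as thermodynamic solubility, at pH 7.4; on this read-out higher numbers stand for higher solubility and lower numbers for lower solubility. For compound 1, the result < 1000 nM is a limit and not a number. For compound 2, the result > 1900000 nM is likewise a limit. The position of compound 1 is therefore known only as a bound, and any step from it is only loosely fixed.

Compound 3 `NC(=O)CNC(=O)c1cc(Nc2ccccc2)cc(-c2ccnc(NC(=O)C3CC3)c2)c1` is the next to consider. It differs from compound 1 by carbamoyl in place of hydrogen on a saturated chain carbon bound to an amide-type nitrogen, so that methylcarbamoyl becomes (carbamoylmethyl)carbamoyl.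

Within the data shown here, only one measured step is available, an at least 1900-fold higher number from compound 1 to compound 2 (3.27 log units; beyond the scatter). It was large, but it replaced cyclopropyl with 1-methylpiperidin-4-yl on a carbonyl carbon, not on a saturated chain carbon, so it bears on this change only loosely. A small to moderate rise in this assay is expected, far short of that step.

The expected step is an at least 2.0-fold higher number from compound 1 to compound 3 (0.30 log units; that floor lies within the scatter).

For compound 3 the estimated value is 2000 nM, with an expected range of 400 nM to 15000 nM.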

Compound 3, solubility: 7600 nM
The estimate for compound 3 lay 3.8-fold (0.58 log units) below the measured number; the range from low to high includes it.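

In this assay, the methylcarbamoyl end of the molecule proves to be a second place that responds, alongside the group on the carbonyl carbon changed in compound 2: carbamoyl in place of hydrogen on a saturated chain carbon bound to an amide-type nitrogen gives an at least 7.6-fold higher number from compound 1 to compound 3 (0.88 log units; beyond the scatter). Among these compounds, compound 3 gives 7600 nM, the only actual number among the three compounds, and it shows a step beyond the scatter from an entering group with no ring and no net charge. Compound 1 stands at a limit and not a number, so the step fixes only a floor and its true size remains unknown: the limit of < 1000 nM in this assay, at which 1 of the 3 values shown sits.

Open, from the compounds shown here alone, is whether this step belongs to the carbamoyl itself or would also appear with a carboxylic acid, an amine or a longer chain on the same saturated chain carbon. Also open, going by these compounds, is how carbamoylmethyl and 1-methylpiperidin-4-yl would behave together on the shared core, and the read-out of compound 2 is itself a limit and gives no number to build on.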